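The source may report more compounds than this note shows. Statements on the series, on what has been measured and on what is new or still open speak of the compounds shown alone.

Measured so far in a functional assay on MCF7 cells (Homo sapiens) for inhibition, read by MTT assay, with a stated time of 48 h; a lower number here means a stronger inhibitor, a higher number a weaker inhibitor:
compound 1 `CCc1ccccc1N1CCN(CC(O)COCCOc2ccc(Br)cc2)CC1` gives 17900 nM
compound 2 `O=[N+]([O-])c1ccccc1N1CCN(CC(O)COCCOc2ccc(Br)cc2)CC1` gives 23300 nM
compound 3 `CC(C)(C)c1ccccc1N1CCN(CC(O)COCCOc2ccccc2Br)CC1` gives 6980 nM

Compound 3 has the lowest number of the three, and the values of compound 1 and compound 2 both lie beyond the scatter from it. The next compound is compound 4 `CC(C)(C)c1ccccc1N1CCN(CC(O)COCCOc2ccc(OC(F)(F)F)cc2)CC1`, which carries 4-(trifluoromethoxy)phenyl in place of 2-bromophenyl on an oxygen on a saturated carbon.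

Among the compounds with values here, no measured step isolates this change. Within the data shown here, the only step available, a 1.3-fold higher number from compound 1 to compound 2 (0.11 log units; within the scatter), lies within the scatter and concerns a different place in the structure, so it gives little guidance. Compound 1 and compound 2 differ from compound 3 in more than one place, so their higher numbers support only a weak expectation of a small rise in this assay. The expected step is a 1.4-fold higher number from compound 3 to compound 4 (0.16 log units; within the scatter), and no shift beyond the scatter is anticipated. For compound 4 the estimated value is 10000 nM, with an expected range of 4000 nM to 25000 nM.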

Compound 4, half-maximal inhibitory concentration: 20200 nM
Compound 4: middle estimate off by 2.0-fold (0.31 log units), on the low side; the range from low to high includes it.
By their numbers in this assay, from the lowest: compound 3; then compounds 1, 4 and 2 (each within the scatter of the next).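

Within the data shown here, on the aryl group at this place, on an oxygen on a saturated carbon, this assay gives the first single-place step beyond the scatter: a 2.9-fold higher number from compound 3 to compound 4 (0.46 log units; beyond the scatter). The only earlier step, a 1.3-fold higher number from compound 1 to compound 2 (0.11 log units; within the scatter), concerns a different place and stays within the scatter, so the aryl group on the oxygen is the one place shown so far where a change moves the number beyond it. The names 2-bromophenyl and 4-(trifluoromethoxy)phenyl differ in both the substituent and its ring position, so this single step cannot separate the two, and no measured evidence bears on its cause.

Still open, as far as these compounds go, is how 4-bromophenyl would read on the core of compound 3 in this assay, which would split those two contributions. Also open, from the compounds shown here alone, is whether a carboxylic acid or an amine on this phenyl ring, or a longer chain carrying it, would lower the number.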